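Benzyl in place of phenyl on a hydroxamic acid inhibitor

The compounds below may be only part of what the source reports. "The series", "measured", "known", "first", "only" and "open" are said of these compounds alone.

Compound 1 `O=C(/C=C/c1ccccc1CSc1nc(O)cc(-c2ccccc2)n1)NO` is a hydroxamic acid that was tested in an assay on isolated protein for inhibition of histone deacetylase HD2 (Zea mays) (a lower number here means a stronger inhibitor, a higher number a weaker inhibitor), where compound 1 gives 367 nM. Among the two numbers known so far this is the higher one, meaning the weaker inhibitor. Its only measured companion, compound 2 `O=C(/C=C/c1cccc(CSc2nc(O)cc(-c3ccccc3)n2)c1)NO`, gives 17 nM in this assay, a much lower number, and the gap between the two lies well beyond the usual scatter of repeated measurements.

Compound 3 `O=C(/C=C/c1ccccc1CSc1nc(O)cc(Cc2ccccc2)n1)NO` has not been measured. It differs from compound 1 in one place: benzyl in place of phenyl on an aromatic carbon. Among the measured compounds shown here, no measured pair in this set shows this particular exchange, so there is no measured step to lean on; the only anchor is the value of compound 1 itself.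

With nothing pointing firmly either way, the expected step of a 1.1-fold higher number from compound 1 to compound 3 (0.06 log units; within the scatter) is estimated to stay within the scatter, with at most a slight move towards a higher number. Compound 3 is therefore expected to give about 420 nM in this assay, with a plausible range from 150 nM to 1200 nM.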

Compound 3, half-maximal inhibitory concentration: 760 nM
Compound 3: the middle estimate sits 1.8-fold (0.26 log units) below what was measured, and the stated range covers the measured number.
By their numbers in this assay, from the lowest: compound 2; then compound 1; then compound 3.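

In this assay, this position on the core proves sensitive to even a small enlargement of the group it carries. Exchanging phenyl for benzyl adds one carbon and keeps the same six-membered aromatic ring, with no hydrogen-bond donors or acceptors on either group, yet it gives a 2.1-fold higher number from compound 1 to compound 3 (0.32 log units; beyond the scatter), a modest weakening that lies beyond the usual scatter. This single pair shows that the exact form of the group on this aromatic carbon matters, but the data at hand offer nothing that explains the step.

On these data alone, whether the number would keep rising with a longer chain, such as phenethyl, remains open, as does what a much smaller group, such as methyl, or a group of a different kind, such as an amine, would do at this carbon. It is also unknown whether benzyl in place of phenyl would bring a step of similar size on compound 2, where the rest of the molecule differs from compound 1.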